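A Vinyl Group Replaces Two Methyls on the Ring

The source may report more compounds than this note shows. Statements on the series, on what has been measured and on what is new or still open speak of the compounds shown alone.

In a functional assay on A549 cells (Homo sapiens) for cytotoxicity (on this read-out higher numbers stand for an effect only at larger amounts of compound and lower numbers for an effect already at smaller amounts), compound 1 `COC1=C(C)C(=O)/C(=C(O)/C=C/c2ccc(Br)cc2)C(=O)C1(C)C` gives 1.4 ug/mL, while compound 2 `COC1=C(C)C(=O)/C(=C(O)/C=C/c2cc(C)cc(C)c2)C(=O)C1(C)C` gives 4.3 ug/mL. Compound 2 therefore holds the higher of the two numbers, and it needs the larger amount to act. Compound 3 `C=Cc1ccccc1/C=C/C(O)=C1/C(=O)C(C)=C(OC)C(C)(C)C1=O` keeps the shared core and changes a single group: 2-vinylphenyl in place of 3,5-dimethylphenyl on a double-bonded chain carbon bound to a double-bonded chain carbon. For the measured compounds named here, only one measured step bears on this change, a swap at the same place, and it gives a 3.1-fold higher number from compound 1 to compound 2 (0.49 log units; beyond the scatter). That step is modest, though beyond the scatter. Neither measured compound carries a vinyl group, so the data give no firm direction. Compound 3 is expected to fall near the two measured values in this assay, with no step beyond the scatter. The estimated step is a 1.4-fold lower number from compound 2 to compound 3 (0.16 log units; within the scatter). For compound 3 the estimated value is 3 ug/mL, with an expected range from 1.2 ug/mL to 7.5 ug/mL.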

Compound 3, concentration for half-maximal effect: 2.2 ug/mL
For compound 3 the middle estimate is 1.4-fold (0.13 log units) above the measured one; low and high end bracket the measured number.
By their numbers in this assay, from the lowest: compounds 1, 3 and 2 (each within the scatter of the next, the first and the last beyond it).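

In this assay the 2-vinylphenyl group of compound 3 cannot be separated from either earlier group, with a 2.0-fold lower number from compound 2 to compound 3 (0.29 log units; within the scatter) and a 1.6-fold higher number from compound 1 to compound 3 (0.20 log units; within the scatter) on the same read-out. Compound 1 and compound 2 do stand apart, with a 3.1-fold higher number from compound 1 to compound 2 (0.49 log units; beyond the scatter), yet compound 3 lies within the scatter of both, so at this place on the chain a ring carrying a vinyl group, with its double bond outside the aromatic ring, keeps the number in the range of the other two. No measurement is available to explain why these groups read alike. Still open, from the compounds shown here alone, is whether a phenyl ring carrying an amine or a carboxylic acid would stay in this range at the same place. Going by these compounds, a longer chain in place of the vinyl group is equally open.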